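The source may report more compounds than this note shows. Statements on the series, on what has been measured and on what is new or still open speak of the compounds shown alone.

The series shares one core, shown by compound 1 `COc1cccc(C(=O)Oc2cc3c(cc2C)[C@@H](C(C)C)CC=C3C)c1`, an ester whose acid part carries a methoxy group on the phenyl ring. In a functional assay on HCT-15 cells (Homo sapiens) for antiproliferative activity, read by sulforhodamine B assay, with a stated time of 48 h, tested at 50 uM (a higher number here means more inhibition at the concentration tested (going by the name of the read-out), a lower number less inhibition), compound 1 gives "not active" (no number reported), and no number accompanies that report. Compound 2 `CC1=CC[C@H](C(C)C)c2cc(C)c(OC(=O)c3cccc(C)c3)cc21`, with 3-methylphenyl on the carbonyl carbon, gives 5.3% in this assay. Compound 3 `CC1=CC[C@H](C(C)C)c2cc(C)c(OC(=O)c3ccc(Cl)cc3)cc21`, with 4-chlorophenyl on the carbonyl carbon, gives 47.4% in this assay. For the measured compounds named here, compound 3 therefore stands highest of the two numbers reported: the single measured step, a number 42.1 percentage points higher from compound 2 to compound 3 (beyond the scatter), is large and beyond the scatter, while compound 1 contributes no number to compare.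

Compound 4 `CC1=CC[C@H](C(C)C)c2cc(C)c(OC(=O)c3ccc([N+](=O)[O-])cc3)cc21` differs from compound 3 in one place: nitro in place of chloro on an aromatic carbon. Going by the values given here, no measured step exchanges chloro for nitro, so the only step available bears on this change loosely at best, in that the 4-chlorophenyl ester gave the higher reading, and it says nothing about a nitro group. With so little to go on, the step of a number 2.4 percentage points lower from compound 3 to compound 4 (within the scatter) is expected to stay within the scatter, in either direction. For compound 4 the estimate in this assay is 45%, with a range from 20% to 70% reflecting the wide uncertainty.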

Compound 4, a percentage reported as inhibition, at one concentration (the size of the read-out at that concentration, not a potency): 67.8%
The estimate for compound 4 lay 22.8 percentage points below the measured number, within the range that was stated.
By their numbers in this assay, from the lowest: compound 2; then compound 3; then compound 4.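

In this assay, the exchange of chloro for nitro on an aromatic carbon, para to a large group, is now a measured step, a number 20.4 percentage points higher from compound 3 to compound 4 (beyond the scatter), so the reading still moves with the group held at this place once the 4-chlorophenyl ester is in hand. The 4-nitrophenyl ester also widens the contrast with the 3-methylphenyl ester, with a number 62.5 percentage points higher from compound 2 to compound 4 (beyond the scatter), a larger step than a number 42.1 percentage points higher from compound 2 to compound 3 (beyond the scatter), and the three numbered compounds now spread across a broad span of this read-out. Nothing in the data given accounts for the difference between nitro and chloro at this place.

Going by these compounds, whether another group on this same carbon, such as an amine, a carboxylic acid or a nitrile, would give a reading above or below that of compound 4 remains open. Compound 1 gives "not active" (no number reported), so steps to it cannot be read, and the methoxy-bearing ester cannot be placed in the order of the other three.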